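Cytotoxicity on Canine Kidney Cells: From Compound 2 to Compound 3

The source may report more compounds than this note shows. Statements on the series, on what has been measured and on what is new or still open speak of the compounds shown alone.

The study tracks tolerance of a shared core in an ADME assay on MDCK cells (Canis lupus familiaris) for cytotoxicity, read by microscopy, with a stated time of 72 h; a higher number here means that more compound is tolerated, a lower number that less compound is tolerated. Compound 1 `COC(=O)C[C@H](NC(=O)OC(C)(C)C)C(=O)N(Cc1ccc(F)cc1)C1(C(=O)NCc2ccccc2)CCN(c2ccccc2)CC1` and compound 2 `COC(=O)C[C@H](NC(=O)OC(C)(C)C)C(=O)N(C)C1(C(=O)NCc2ccccc2)CCN(Cc2ccccc2)CC1` were both measured. In this assay compound 1 gives 20000 nM. In this assay compound 2 gives 20000 nM, which is level with compound 1 at the digits shown, so the two values show no change beyond the scatter. Within the data shown here, no single-point step connects compound 1 and compound 2, so only their two values can be compared.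

Compound 3 `COC(=O)C[C@H](NC(=O)OC(C)(C)C)C(=O)N(Cc1ccc(Cl)cc1)C1(C(=O)NCc2ccccc2)CCN(Cc2ccccc2)CC1` has not yet been measured in this assay. It differs from compound 2 in one place: 4-chlorophenyl in place of hydrogen on a saturated chain carbon bound to an amide-type nitrogen. Among the measured compounds shown here, both compounds measured so far sit at the same reading in this assay, and nothing in the data indicates that any alteration at this position shifts the result. Compound 3 is therefore expected to stay within the scatter of compound 2, with a step of no change at the digits printed from compound 2 to compound 3 (within the scatter) of essentially none. The estimate for compound 3 in this assay is 20000 nM, with a range from 10000 nM to 40000 nM.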

Compound 3, minimum cytotoxic concentration: 100000 nM
The estimate for compound 3 lay 5.0-fold (0.70 log units) below the measured number; the measured number lies above the stated range.
By their numbers in this assay, from the lowest: compounds 1 and 2 (each within the scatter of the next); then compound 3.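

Replacing hydrogen with 4-chlorophenyl on a saturated chain carbon bound to an amide-type nitrogen gives a 5.0-fold higher number from compound 2 to compound 3 (0.70 log units; beyond the scatter) in this assay and so moves the reading beyond the scatter. Among these compounds, this is the first sign that the position can change how much compound is tolerated: compounds 1 and 2 read level but differ in more than one place, so they could not isolate it, whereas compounds 2 and 3 differ here alone, the same change read one bond further out as methyl to 4-chlorobenzyl. The data offer no measurement that explains why the number rises at this position.

On these data alone, what remains open is which part of the 4-chlorobenzyl group goes with the higher number, whether the aromatic ring, the chlorine or simply the larger group at this place. A plain benzyl, a longer saturated chain such as butyl, or a chain ending in an amine or a carboxylic acid would each test a different one of these readings, and the direction of the step for any of them cannot be told from the present compounds.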